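Aromatase inhibition: a triazole swap from hexyl to methylphenoxy

The compounds below may be only part of what the source reports. "The series", "measured", "known", "first", "only" and "open" are said of these compounds alone.

Compound 1 `N#Cc1ccc(C(c2ccc(C#N)cc2)n2cc(COc3ccc(Cl)cc3)nn2)cc1`: 16100 nM
Compound 2 `N#Cc1ccc(C(c2ccc(C#N)cc2)n2cc(COc3ccc([N+](=O)[O-])cc3)nn2)cc1`: 7730 nM
Compound 3 `CCCCCCCc1cn(C(c2ccccc2)c2ccccc2)nn1`: 19400 nM

Of the compounds shown here, three have been measured in an assay on isolated protein for inhibition of Aromatase (Homo sapiens), read by fluorescence and colorimetric assay, with a stated time of 30 min; on this read-out lower numbers stand for stronger inhibition and higher numbers for weaker inhibition. Going by the values given here, compound 1 gives 16100 nM and compound 2 gives 7730 nM; the one measured step between them, a 2.1-fold lower number from compound 1 to compound 2 (0.32 log units; beyond the scatter), is a modest change that concerns the aryl ether substituent. Compound 3, which carries a heptyl chain on the triazole instead of an aryloxymethyl group, gives 19400 nM. Its number sits close to that of compound 1, within the usual scatter, while its gap to compound 2 lies beyond the scatter.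

The next compound, compound 4 `Cc1ccc(OCc2cn(C(c3ccccc3)c3ccccc3)nn2)cc1`, differs from compound 3 in one place: 4-methylphenoxy in place of hexyl on a saturated chain carbon bound to an aromatic carbon. Among the compounds with values here, no measured step covers this change; the only measured step, the nitro-for-chloro exchange, speaks to a different position and was itself small. What the data offer is that compounds with an aryloxymethyl triazole and compound 3 with its heptyl chain all give numbers of a similar order. An expected step of a 1.4-fold lower number from compound 3 to compound 4 (0.14 log units; within the scatter) follows, not beyond the scatter. Compound 4 is therefore estimated at 14000 nM, with a range from 5000 nM to 40000 nM.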

Compound 4, half-maximal inhibitory concentration: 26800 nM
For compound 4 the middle estimate is 1.9-fold (0.28 log units) below the measured one, and the stated range covers the measured number.
By their numbers in this assay, from the lowest: compound 2; then compounds 1, 3 and 4 (each within the scatter of the next).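

At this place, on a saturated chain carbon bound to an aromatic carbon, 4-methylphenoxy in place of hexyl gives a 1.4-fold higher number from compound 3 to compound 4 (0.14 log units; within the scatter) in this assay. The earlier compounds had shown a change only on the aromatic carbon of the aryl ether, so this is the first reading at the chain itself. It shows that a straight hexyl and a 4-methylphenoxy, which brings in a six-membered aromatic ring of carbon only and a hydrogen-bond acceptor, cannot be told apart on this read-out, at least with the core of compound 3. Nothing available explains why the two groups read alike.

The compounds shown leave open whether an amine, a carboxylic acid or a longer chain at this place would shift the number beyond the scatter. They also leave open whether a nitro group on the phenoxy ring of compound 4 would repeat the modest gain seen in a 2.1-fold lower number from compound 1 to compound 2 (0.32 log units; beyond the scatter), since that step was read only on the core of compound 1.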